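The compounds below may be only part of what the source reports. "The series", "measured", "known", "first", "only" and "open" are said of these compounds alone.

Compound 3, with the structure `COc1cc(CC(O)c2ccc(-c3ccc(Cl)cc3)cc2)c([N+](=O)[O-])cc1OC`, gives 4100 nM in an ADME assay on HeLa Rh cells (Homo sapiens) for cytotoxicity, read by microscopy; on this read-out higher numbers stand for lower toxicity in this test and lower numbers for higher toxicity in this test. On the numbers shown it stands level with compound 1, whose structure is `COc1cc(CC(O)c2ccc(-c3ccc(C(F)(F)F)cc3)cc2)c([N+](=O)[O-])cc1OC` and which gives 4100 nM in this assay, so that no change at the digits printed from compound 1 to compound 3 (within the scatter). Compound 2, with the structure `COc1ccc(-c2ccc(C(O)Cc3cc(OC)c(OC)cc3[N+](=O)[O-])cc2)cc1`, gives only > 244000 nM in this assay, which is a limit rather than a number; its value sits at the limit of > 244000 nM in this assay, at which 1 of the 3 values shown sits. The exchange from compound 2 to compound 3 brought an at least 59-fold lower number from compound 2 to compound 3 (1.77 log units; beyond the scatter).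

Compound 4, with the structure `COc1cc(CC(O)c2ccc(-c3cccc(F)c3)cc2)c([N+](=O)[O-])cc1OC`, is not yet measured. It differs from compound 3 in one place: 3-fluorophenyl in place of 4-chlorophenyl on an aromatic carbon. Two kinds of step bear on this change. One halogen replacing another, or replacing trifluoromethyl, gave no change at the digits printed from compound 1 to compound 3 (within the scatter), whereas the step to methoxy gave an at least 59-fold higher number from compound 1 to compound 2 (1.77 log units; beyond the scatter). Since compound 4 keeps a halogen on the same phenyl, the halogen swap seen from compound 1 to compound 3 is the closer precedent, and no step beyond the scatter is expected in this assay. Compound 4 is therefore expected to give about 5000 nM, most likely between 2000 nM and 15000 nM. The expected step is a 1.2-fold higher number from compound 3 to compound 4 (0.09 log units; within the scatter).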

Compound 4, half-maximal cytotoxic concentration: 7400 nM
For compound 4 the middle estimate is 1.5-fold (0.17 log units) below the measured one; the measured number falls inside the stated range.
By their numbers in this assay, from the lowest: compounds 1, 3 and 4 (each within the scatter of the next). At a limit, above all of these: compound 2.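

The result shows that, in this assay, the halogen on this phenyl can differ in identity and in place without a step beyond the scatter: 3-fluorophenyl in place of 4-chlorophenyl gives a 1.8-fold higher number from compound 3 to compound 4 (0.26 log units; within the scatter), and in place of 4-(trifluoromethyl)phenyl it gives a 1.8-fold higher number from compound 1 to compound 4 (0.26 log units; within the scatter). The gap to the methoxy compound also holds for this new group, with 3-fluorophenyl in place of 4-methoxyphenyl giving an at least 32-fold lower number from compound 2 to compound 4 (1.51 log units; beyond the scatter), so among the four compounds the halogen and trifluoromethyl compounds 1, 3 and 4 sit together and compound 2 goes against them. Compound 2 still stands only at a limit of the assay and not at a number: the limit of > 244000 nM in this assay, at which 1 of the 4 values shown sits.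

Compound 4 alters the halogen and its place in a single step, and the compounds shown cannot separate these two changes or say whether the methoxy group would behave the same way in the place held by fluorine in compound 4. They also leave open whether an amine, a carboxylic acid or a hydroxyl on this phenyl would fall with compound 2 or with compounds 1, 3 and 4.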